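Swapping the Amino Side Chain for a Dimethylpiperidine

The source may hold more compounds than are shown below. What is called first, only, known or untested is meant among the compounds shown, and "the series" means these compounds.

Measured compounds:
- compound 1, `CCCCNc1nc(C(F)(F)F)ccc1CNC(=O)C(C)c1ccc(NS(C)(=O)=O)c(F)c1`: 9.1 nM
- compound 2, `CC(C(=O)NCc1ccc(C(F)(F)F)nc1NCc1cccnc1)c1ccc(NS(C)(=O)=O)c(F)c1`: "not active" (no number reported)

In a functional assay on CHO-K1 cells for antagonist activity at transient receptor potential cation channel subfamily V member 1 (Homo sapiens), read by FLIPR (a higher number here means a weaker inhibitor, a lower number a stronger inhibitor), compound 1 gives 9.1 nM, a strong result. Compound 2 stands apart: in this assay compound 2 was reported as "not active" (no number reported), so no number exists for it and its standing cannot be placed on the scale at all; it only marks the weak end of what has been seen so far.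

Compound 3, `CC(C(=O)NCc1ccc(C(F)(F)F)nc1N1CCC(C)(C)CC1)c1ccc(NS(C)(=O)=O)c(F)c1`, has not yet been tested. Its difference from compound 2 is 4,4-dimethylpiperidin-1-yl in place of ((pyridin-3-yl)methyl)amino on an aromatic carbon. The group that leaves is the one carrying the hydrogen-bond donor and the extra aromatic ring; the group that enters is a saturated ring without a donor.

Because compound 2 shows only "not active" (no number reported), no step size can be computed, and the direction must be judged from compound 1, whose 9.1 nM shows that a strong result at this position is possible. A large move towards stronger inhibition is expected for compound 3. In this assay compound 3 is estimated at 30 nM, with a likely range from 5 nM to 300 nM.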

Compound 3, inhibition constant: 0.3 nM
Beside the measured number, compound 3's estimate is 100-fold (2.00 log units) above it; measured number below the stated range.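

In this assay the change from butylamino to 4,4-dimethylpiperidin-1-yl gives a 30-fold lower number from compound 1 to compound 3 (1.48 log units; beyond the scatter) and lies beyond the scatter, so the aromatic carbon next to the ring nitrogen can hold a saturated ring and still give a very low number. The entering group has no hydrogen-bond donor, which shows that a donor on this carbon is not needed for strong inhibition, and the comparison with compound 2 adds that heavy-atom count alone does not settle the outcome: the ((pyridin-3-yl)methyl)amino group and the 4,4-dimethylpiperidin-1-yl group are equal in that count, yet only compound 3 has a number, so the step from compound 2 to compound 3 cannot be read. Nothing shown here gives a measured reason for the gain.

Going by these compounds, what stays open is whether the gain depends on the two methyl groups or on the ring itself, a question that plain piperidine or morpholine at this carbon would address. On these data alone, it is also open whether an open-chain group such as diethylamino, which likewise has no hydrogen on its nitrogen, would behave like the ring.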